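Swapping a benzyl ether for a directly bound aryl ring

The compounds below may be only part of what the source reports. "The series", "measured", "known", "first", "only" and "open" are said of these compounds alone.

Three compounds have been measured in a functional assay on HEK293 cells for agonist activity at G-protein coupled receptor 39 (Homo sapiens), read by scintillation proximity assay and inositol phosphate accumulation, with a stated time of 75 min, in the presence of a further agent that is not named here; on this read-out higher numbers stand for an effect only at larger amounts of compound and lower numbers for an effect already at smaller amounts:
Compound 1: `Cc1nn(-c2ncnc3nc[nH]c23)c2c1C(C(=O)N(C)c1ccccc1)CC(=O)N2`, giving 32 nM.
Compound 2: `Cc1nn(-c2ncnc3nc[nH]c23)c2c1C(OCCc1ccccc1)CC(=O)N2`, giving 3 nM.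
Compound 3: `Cc1nn(-c2ncnc3nc[nH]c23)c2c1C(OCc1ccccc1Cl)CC(=O)N2`, giving 2 nM.

Compound 3 has the lowest number of the three. Against compound 1 its step is a 16-fold lower number from compound 1 to compound 3 (1.20 log units; beyond the scatter), but against compound 2 the step is a 1.5-fold lower number from compound 2 to compound 3 (0.18 log units; within the scatter), so compound 2 and compound 3 cannot be told apart. Compound 4, `Cc1nn(-c2ncnc3nc[nH]c23)c2c1C(c1ccc(F)cc1Cl)CC(=O)N2`, differs from compound 3 in that (2-chloro-4-fluorophenyl in place of (2-chlorobenzyl)oxy on a saturated ring carbon). Going by these compounds, the large steps of an 11-fold lower number from compound 1 to compound 2 (1.03 log units; beyond the scatter) and a 16-fold lower number from compound 1 to compound 3 (1.20 log units; beyond the scatter) concern replacing a carbamoyl group by an ether, and the small step of a 1.5-fold lower number from compound 2 to compound 3 (0.18 log units; within the scatter) concerns the aryl ring only; none removes the ether oxygen itself, so that change is untested. A modest rise is expected, a 5.0-fold higher number from compound 3 to compound 4 (0.70 log units; beyond the scatter), so compound 4 is estimated at 10 nM, within 2 nM to 50 nM.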

Compound 4, half-maximal effective concentration: 9 nM
Compound 4: the middle estimate sits 1.1-fold (0.05 log units) above what was measured; measured number inside the range.
By their numbers in this assay, from the lowest: compounds 3 and 2 (each within the scatter of the next); then compound 4; then compound 1.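

In this assay, a 2-chloro-4-fluorophenyl bound directly to this saturated ring carbon keeps a low number without any ether link, though at a cost: a 4.5-fold higher number from compound 3 to compound 4 (0.65 log units; beyond the scatter) and a 3.0-fold higher number from compound 2 to compound 4 (0.48 log units; beyond the scatter). Even so, the directly bound ring improves on the amide group, with a 3.6-fold lower number from compound 1 to compound 4 (0.55 log units; beyond the scatter). No measurement here explains these steps. The fluorine enters as the ether oxygen leaves, so the two changes cannot be separated. Going by these compounds, whether an amine or a carboxylic acid would be accepted at this carbon remains open.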